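The compounds below may be only part of what the source reports. "The series", "measured", "known", "first", "only" and "open" are said of these compounds alone.

In a functional assay on DU-145 cells (Homo sapiens) for cytotoxicity, read by CCK-8 assay (a higher number here means a weaker inhibitor, a lower number a stronger inhibitor), compound 1, with the structure `Oc1ccc(-c2cc(-c3ccsc3)cc(-c3ccc(O)cc3)n2)cc1`, gives 2060 nM. Compound 2, with the structure `Oc1ccc(-c2cc(-c3ccccn3)cc(-c3ccc(O)cc3)n2)cc1`, differs from it by a pyridin-2-yl in place of the thiophen-3-yl, and in this assay compound 2 reaches only the limit > 50000 nM, which is not a number but the edge of what the assay reports. So the step of an at least 24-fold higher number from compound 1 to compound 2 (1.38 log units; beyond the scatter) is large, and compound 2 stands at the weaker end of the two values shown; the limit of > 50000 nM in this assay, at which 1 of the 2 values shown sits, is where its value sits.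

Compound 3, with the structure `Oc1ccc(-c2cc(-c3cccnc3)cc(-c3ccc(O)cc3)n2)cc1`, keeps everything else and changes only the heteroaryl group: pyridin-3-yl in place of pyridin-2-yl on an aromatic carbon. Among the measured compounds shown here, the only measured step that bears on this position is the one from compound 1 to compound 2, which was large and went toward weaker inhibition. Compound 3 is expected to lie somewhere between that pair, so the step of an at least 3.3-fold lower number from compound 2 to compound 3 (0.52 log units; beyond the scatter) is estimated to favour stronger inhibition. For compound 3 the estimate in this assay is 15000 nM, within a range from 3000 nM to 60000 nM.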

Compound 3, half-maximal inhibitory concentration: 240 nM
Estimate against measurement, compound 3: 63-fold (1.80 log units) above, and the stated range ends above it.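

In this assay, the two pyridine groups have the same atoms and differ only in how the ring is attached, pyridin-3-yl against pyridin-2-yl, yet the result is an at least 200-fold lower number from compound 2 to compound 3 (2.31 log units; beyond the scatter). At this position, opposite the ring nitrogen of the shared core, the activity therefore depends on the attachment of the pyridine and not merely on its presence, although compound 2 carries only a limit of the assay and not a number: the limit of > 50000 nM in this assay, at which 1 of the 3 values shown sits.

The pyridin-3-yl group also improves on the thiophen-3-yl group, with an 8.6-fold lower number from compound 1 to compound 3 (0.93 log units; beyond the scatter), so the large loss seen earlier with pyridin-2-yl was not a general penalty for putting a pyridine in place of the thiophene.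

The compounds shown cannot explain why moving the attachment point has such a large effect, as they give no measured property of these groups that would account for it. Going by these compounds, it also remains open how a pyridin-4-yl group, a plain phenyl ring or a small amine at this same position would compare with the pyridin-3-yl group of compound 3.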